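Swapping a methoxy for a nitro on a weakly cytotoxic coumarin ether

This account rests on a few compounds, and the source may have more. Where it says the series, first, only, none or still open, it means among the compounds named here.

Two compounds sharing one core have been examined in a functional assay on HL-60 cells (Homo sapiens) for cytotoxicity, read by MTT assay, with a stated time of 48 h; on this read-out lower numbers stand for stronger inhibition and higher numbers for weaker inhibition. Compound 1, `O=c1ccc2cc(OCc3cc(-c4ccc([N+](=O)[O-])cc4)no3)ccc2o1`, gives 55800 nM in this assay. Compound 2, `COc1ccc(-n2cc(COc3ccc4oc(=O)ccc4c3)nn2)cc1`, gives 46400 nM in this assay. These two numbers are close enough to lie within the usual scatter, so neither compound can be called the stronger of the pair; both are weak.

Compound 3, `O=c1ccc2cc(OCc3cn(-c4ccc([N+](=O)[O-])cc4)nn3)ccc2o1`, is the next compound to be tested. It differs from compound 2 in one place: nitro in place of methoxy on an aromatic carbon, on an aromatic carbon of a six-membered aromatic ring of carbon only, para to a large group. Since compound 1 already carries the same nitrophenyl and sits in the same weak range, no step beyond the scatter is expected from compound 2 to compound 3, with the estimated step of a 1.1-fold higher number from compound 2 to compound 3 (0.03 log units; within the scatter). For compound 3 in this assay the expected value is 50000 nM, between 20000 nM and 120000 nM.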

Compound 3, half-maximal inhibitory concentration: 46000 nM
For compound 3 the middle estimate is 1.1-fold (0.04 log units) above the measured one, within the range that was stated.
By their numbers in this assay, from the lowest: compounds 3, 2 and 1 (each within the scatter of the next).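

In this assay, nitro in place of methoxy on an aromatic carbon, para to a large group, gives a 1.0-fold lower number from compound 2 to compound 3 (0.00 log units; within the scatter). Going by these compounds alone, this is the first view of this change on its own, since compound 1 and compound 2 differ in more than one place, and here 4-methoxyphenyl and 4-nitrophenyl cannot be told apart by their numbers. Nothing available explains why the two groups read alike in this assay.

From the compounds shown here alone, what remains open is whether any group at this position can move the number beyond the scatter, for example an amine, a carboxylic acid or a longer chain such as butoxy. This single pair also cannot show whether the two groups would still read alike on a different core or in other cells.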